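Swapping an Ethyl for a Thiophene on a Sulfonyl Group

The source may report more compounds than this note shows. Statements on the series, on what has been measured and on what is new or still open speak of the compounds shown alone.

Three compounds share one core and differ only in the group on one ring nitrogen. Compound 1 `CC(=O)N1CCN(c2ccc(OCC3CCN(C(=O)OC(C)C)CC3)cn2)CC1` carries an acetyl group there; in a functional assay on CHO-K1 cells for agonist activity at Glucose-dependent insulinotropic receptor (Homo sapiens), read by a luciferase reporter, with a stated time of 5 h (a lower number here means that less compound is needed, a higher number that more compound is needed for the effect), compound 1 gives only a limit, > 10000 nM. Compound 2 `CCS(=O)(=O)N1CCN(c2ccc(OCC3CCN(C(=O)OC(C)C)CC3)cn2)CC1` carries an ethylsulfonyl group, and in this assay compound 2 gives 1300 nM. Compound 3 `CCCCS(=O)(=O)N1CCN(c2ccc(OCC3CCN(C(=O)OC(C)C)CC3)cn2)CC1` carries a butylsulfonyl group; in this assay compound 3 gives 100 nM. Of the two plain numbers, compound 2 stands highest, since there is a 13-fold lower number from compound 2 to compound 3 (1.11 log units; beyond the scatter). Compound 1 sits at the limit of > 10000 nM in this assay, at which 1 of the 3 values shown sits.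

Compound 4 `CC(C)OC(=O)N1CCC(COc2ccc(N3CCN(S(=O)(=O)c4cccs4)CC3)nc2)CC1` takes the next step from compound 2: thiophen-2-yl in place of ethyl on a sulfonyl sulfur. The measured step that bears on it is a 13-fold lower number from compound 2 to compound 3 (1.11 log units; beyond the scatter), where lengthening the chain on the sulfonyl sulfur brought the number down sharply. Compound 4, which also enlarges the group on the sulfonyl sulfur, is expected to show a 6.5-fold lower number from compound 2 to compound 4 (0.81 log units; beyond the scatter). Compound 4 is therefore estimated at 200 nM, with a likely range from 40 nM to 1000 nM.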

Compound 4, half-maximal effective concentration: 1800 nM
Estimate against measurement, compound 4: 9.0-fold (0.95 log units) below, outside the stated range (above it).
By their numbers in this assay, from the lowest: compound 3; then compounds 2 and 4 (each within the scatter of the next). At a limit, above all of these: compound 1.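

Putting thiophen-2-yl in place of ethyl on the sulfonyl sulfur leaves the reading in this assay within the scatter (a 1.4-fold higher number from compound 2 to compound 4 (0.14 log units; within the scatter)). Enlarging the group on this sulfur therefore does not by itself bring the number down, as butyl and thiophen-2-yl part clearly (an 18-fold higher number from compound 3 to compound 4 (1.26 log units; beyond the scatter)). The sulfonyl link with thiophen-2-yl still compares well with acetyl, although that comparison rests on a limit for compound 1 and so gives only a minimum (an at least 5.5-fold lower number from compound 1 to compound 4 (0.74 log units; beyond the scatter)).

No measurement shown here explains why butyl and thiophen-2-yl differ. On these data alone, it remains open how a phenyl ring or a longer chain such as hexyl on the sulfonyl sulfur would compare with butyl and thiophen-2-yl.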